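Chalcone series: methyl removal on the benzyl ether

The source may report more compounds than this note shows. Statements on the series, on what has been measured and on what is new or still open speak of the compounds shown alone.

Measured compounds:
compound 1 `O=C(/C=C/c1ccc(F)cc1)c1ccc(OCc2ccccc2)cc1` — "not determined" (no result reported) in a functional assay on HCT-116 cells (Homo sapiens) for antiproliferative activity, read by sulforhodamine B assay, with a stated time of 3 days, tested at 50 uM; on this read-out lower numbers stand for a weaker effect and higher numbers for a stronger effect at the one concentration tested
compound 2 `Cc1ccc(COc2ccc(C(=O)/C=C/c3ccccc3)cc2)cc1` — "not determined" (no result reported) in this assay
compound 3 `Cc1ccc(COc2ccc(C(=O)/C=C/c3ccc(F)cc3)cc2)cc1` — 15.4%

Compound 2 stands at "not determined" (no result reported) in this assay; compound 1 likewise gives "not determined" (no result reported), so within the series only compound 3 supplies an anchor, with 15.4% in this assay. Compound 4 `O=C(/C=C/c1ccccc1)c1ccc(OCc2ccccc2)cc1` differs from compound 2 by hydrogen in place of methyl on an aromatic carbon. Within the data shown here, no step between measured compounds covers this change, so its size in this assay cannot be read from the series; no shift beyond the usual scatter is expected in either direction. Resting on compound 3 alone, compound 4 is expected to give about 14% in this assay, with an estimated range from 0% to 35%.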

Compound 4, a percentage reported as inhibition, at one concentration (the size of the read-out at that concentration, not a potency): 33.8%
Beside the measured number, compound 4's estimate is 19.8 percentage points below it, within the range that was stated.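

In this assay, among these compounds, compound 2 carries no single number, so no step to compound 4 at 33.8% can be read. The compounds shown leave open what the change from 4-methylbenzyl to benzyl does to this read-out. No further evidence bears on this result.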